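The source may hold more compounds than are shown below. What is called first, only, known or untested is meant among the compounds shown, and "the series" means these compounds.

Series notes. Within the data shown here, in an assay on isolated protein for inhibition of DNA topoisomerase 1 (Homo sapiens), with a stated time of 30 min, tested at 100 uM (on this read-out higher numbers stand for more inhibition at the one concentration tested (going by the name of the read-out) and lower numbers for less inhibition), compound 3 `Cc1ccc(S(=O)(=O)n2c(-c3ccccc3)c(C#CCO[C@H]3C[C@H](N)[C@@H](O)[C@H](C)O3)c3ccccc32)cc1` gives 92.8%, the highest of the three numbers measured so far. Compound 1 `Cc1ccc(S(=O)(=O)n2c(-c3ccccc3)c(C#CCO[C@H]3CC[C@H](N)[C@H](C)O3)c3ccccc32)cc1` gives 43.2%, and compound 2 `C[C@@H]1O[C@@H](OCC#Cc2c(-c3ccccc3)[nH]c3ccccc23)C[C@H](N)[C@@H]1O` gives 8.8%. Among the measured compounds shown here, the only measured step between neighbours, a number 49.6 percentage points higher from compound 1 to compound 3 (beyond the scatter), put one six-membered non-aromatic ring of 9 heavy atoms in place of one of 8 heavy atoms on an oxygen on a saturated carbon. Compound 4 `Cc1ccc(S(=O)(=O)n2c(-c3ccccc3)c(C#CCO[C@H]3C[C@H](N)[C@H](O)[C@H](C)O3)c3ccccc32)cc1` keeps every atom and bond of compound 3 and differs in configuration only: the two compounds have the same atoms and bonds and differ only in configuration as drawn: 1 of 4 stereo elements differ; a stereocentre at a saturated ring carbon is drawn R in compound 3 and S in compound 4. For the measured compounds named here, no measured step inverts a single stereocentre, so the one step in hand does not bear directly on this change; no step beyond the scatter is expected in this assay, with a modest fall the likelier side. Compound 4 is therefore estimated at 80%, range 50% to 98%, the expected step being a number 12.8 percentage points lower from compound 3 to compound 4 (beyond the scatter).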

Compound 4, a percentage reported as inhibition, at one concentration (the size of the read-out at that concentration, not a potency): 80.1%
Estimate against measurement, compound 4: 0.1 percentage points below; measured number inside the range.
By their numbers in this assay, from the lowest: compound 2; then compound 1; then compound 4; then compound 3.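

Configuration at this saturated ring carbon matters on its own, with a number 12.7 percentage points lower from compound 3 to compound 4 (beyond the scatter), and the step can be put down to that stereocentre because nothing else separates the pair: the fact that compounds 3 and 4 differ only in the configuration as drawn. Among these compounds, the S form also gives the first reading on the aromatic nitrogen, with a number 71.3 percentage points higher from compound 2 to compound 4 (beyond the scatter) for (4-methylphenyl)sulfonyl in place of hydrogen. The larger ring group keeps its lead in this form, with a number 36.9 percentage points higher from compound 1 to compound 4 (beyond the scatter) on the oxygen on a saturated carbon.

Still open, on these data alone, is how the other three stereo elements behave. Also open, as far as these compounds go, is whether a methanesulfonyl group on that nitrogen would read like (4-methylphenyl)sulfonyl.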